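Inverting Two Stereocentres of Compound 1

A few compounds are considered here, and "the series" means these few. Any claim that something is new, unique, unknown or untested is made for them only; others in the source may bear on it.

Compound 1, `O=C(O)[C@H]1NC[C@@H](O)[C@H](O)[C@H]1O`, was examined in an assay for inhibition of alpha-N-acetylgalactosaminidase (Gallus gallus), tested at 1000 uM; a higher number here means more inhibition at the concentration tested (going by the name of the read-out), a lower number less inhibition. In this assay compound 1 gives 4.2%, the larger of the two readings taken so far, though the difference to the other reading stays within the scatter of repeated measurements. That other compound, compound 2, `O=C(O)[C@@H]1NCC=C[C@@H]1O`, gives 1.3% in this assay. Both readings are small for the high concentration used, and the two compounds cannot be separated on these numbers.

Within the data shown here, compound 3, `O=C(O)[C@H]1NC[C@H](O)[C@H](O)[C@@H]1O`, has not yet been measured. the two compounds have the same atoms and bonds and differ only in configuration as drawn: 2 of 4 stereo elements differ; a stereocentre at a saturated ring carbon is drawn R in compound 1 and S in compound 3; a stereocentre at a saturated ring carbon is drawn S in compound 1 and R in compound 3 No step between two measured compounds is available, so nothing shows how an inversion of this kind moves the reading in this assay. Both measured compounds lie close to the floor of the read-out, and compound 3 shares every atom and bond with compound 1, so the expected step of a number 0.8 percentage points higher from compound 1 to compound 3 (within the scatter) is estimated to be none beyond the scatter. In this assay compound 3 is expected to give about 5%, with a likely range from -5% to 18%.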

Compound 3, a percentage reported as inhibition, at one concentration (the size of the read-out at that concentration, not a potency): 4.5%
Compound 3: the middle estimate sits 0.5 percentage points above what was measured; the range from low to high includes it.
By their numbers in this assay, from the lowest: compounds 2, 1 and 3 (each within the scatter of the next).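

Among these compounds, until now no pair of measured compounds differed in one place, so nothing showed how a change in configuration moves the reading. In this assay, swapping the drawn configuration at two saturated ring carbons gives a number 0.3 percentage points higher from compound 1 to compound 3 (within the scatter), so at this high test concentration the two arrangements cannot be told apart and neither stands clear of the other. The comparison is a clean one because nothing else separates the pair: the fact that compounds 1 and 3 differ only in the configuration as drawn.

The compounds shown leave open whether inverting only one of these two stereocentres, or either of the other two stereo elements, would give a reading beyond the scatter, since a single double inversion cannot show what each centre does alone and both readings lie close to the floor of the read-out. They also leave open whether any change to the groups themselves would lift the reading clear of that floor, for example an amide or a methyl ester in place of the carboxylic acid, or a longer chain on the ring nitrogen.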